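Nitro in Place of Trifluoromethyl: What to Expect

This account rests on a few compounds, and the source may have more. Where it says the series, first, only, none or still open, it means among the compounds named here.

Compound 3 `COc1cc(C(=O)c2sc(-c3ccc(C(F)(F)F)cc3)cc2N)cc(OC)c1OC` gives 370 nM in a functional assay on L1210 cells (Mus musculus) for antiproliferative activity (a lower number here means a stronger inhibitor, a higher number a weaker inhibitor), the highest number among the three measured compounds. Compound 1 `COc1cc(C(=O)c2sc(-c3ccc(F)cc3)cc2N)cc(OC)c1OC` gives 20 nM, and compound 2 `COc1cc(C(=O)c2sc(-c3ccc(Cl)c(Cl)c3)cc2N)cc(OC)c1OC` gives 260 nM. The step of a 19-fold higher number from compound 1 to compound 3 (1.27 log units; beyond the scatter) was large, whereas a 1.4-fold higher number from compound 2 to compound 3 (0.15 log units; within the scatter) stayed within the scatter, so exchanging one substituted phenyl group for another on the aromatic carbon changed little. Compound 4 `COc1cc(C(=O)c2sc(-c3ccc([N+](=O)[O-])cc3)cc2N)cc(OC)c1OC` carries the change (nitro in place of trifluoromethyl on an aromatic carbon). For the measured compounds named here, no measured compound holds a nitro group, so the only guide is that a comparable exchange, seen in a 1.4-fold higher number from compound 2 to compound 3 (0.15 log units; within the scatter), left the number nearly unchanged. For compound 4 a step of a 1.5-fold lower number from compound 3 to compound 4 (0.17 log units; within the scatter) is therefore expected, staying close to the scatter. The estimate for compound 4 is 250 nM, with a range from 80 nM to 800 nM.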

Compound 4, half-maximal inhibitory concentration: 100 nM
For compound 4 the middle estimate is 2.5-fold (0.40 log units) above the measured one; low and high end bracket the measured number.
By their numbers in this assay, from the lowest: compound 1; then compound 4; then compounds 2 and 3 (each within the scatter of the next).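

In this assay nitro in place of trifluoromethyl gives a 3.7-fold lower number from compound 3 to compound 4 (0.57 log units; beyond the scatter) and so shows that this position can tell these two groups apart, which the earlier exchange of substituted phenyl groups did not suggest. The 4-nitrophenyl group in place of 3,4-dichlorophenyl gives a 2.6-fold lower number from compound 2 to compound 4 (0.41 log units; beyond the scatter) where 4-(trifluoromethyl)phenyl stayed within the scatter, while nitro in place of fluoro still gives a 5.0-fold higher number from compound 1 to compound 4 (0.70 log units; beyond the scatter) and leaves fluoro ahead. Nothing available here explains these differences.

Going by these compounds, whether an amine, a methoxy group or a carboxylic acid at this position would come closer to fluoro remains open.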